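This account rests on a few compounds, and the source may have more. Where it says the series, first, only, none or still open, it means among the compounds named here.

Compound 1 `Cc1cc(/C=C2\S/C(=N\c3ccccc3)N(C3CCCCC3)C2=O)c(C)n1-c1ccccc1` gives > 200000 nM in an ADME assay on L6 cells (Rattus norvegicus) for cytotoxicity, read by microscopy and resazurin assay, with a stated time of 72 h (a higher number here means that more compound is needed for the effect, a lower number that less compound is needed), which is a limit of the assay and not a number. Compound 2 `O=C1/C(=C/c2ccn(Cc3ccccc3)c2)S/C(=N\c2ccccc2)N1C1CCCCC1` gives > 200000 nM in this assay, also a limit. Compound 3 `Cc1cc(/C=C2\S/C(=N\c3ccccc3)N(C)C2=O)c(C)n1-c1ccccc1` gives > 230000 nM in this assay, again a limit.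

Compound 3 comes from compound 1 by methyl in place of cyclohexyl on an amide-type nitrogen in a ring. The step that the two limits leave unreadable from compound 1 to compound 3 cannot be read because the limit of > 200000 nM in this assay, at which 2 of the 3 values shown sit, holds compound 1 and the limit of > 230000 nM in this assay, at which 1 of the 3 values shown sits, holds compound 3. Compound 4 `CN1C(=O)/C(=C/c2ccn(Cc3ccccc3)c2)S/C1=N\c1ccccc1` is not yet measured; it comes from compound 2 by methyl in place of cyclohexyl on an amide-type nitrogen in a ring, the same change at the same place. The difference between the cores of compound 1 and compound 2 is not broken down here. For compound 4 the expected step is a number no higher from compound 2 to compound 4 (the limit leaves the size open), resting on the unreadable step that the two limits leave unreadable from compound 1 to compound 3 for the same change. Compound 4 is expected at 200000 nM, between 100000 nM and 400000 nM, most likely again reported only as a limit.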

Compound 4, half-maximal effective concentration: > 240000 nM
Compound 4 ended at the assay's limit; the forecaster's own chance of this, stated with the estimate: 85%; middle value at least 1.2-fold (0.07 log units) from the limit.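

Going by these compounds alone, compound 2 and compound 4 each give only a limit of the assay and not a number, and no step between them can be read. The compounds shown leave open how much of any of them is needed for the effect in this assay, and whether methyl in place of cyclohexyl changes that amount at all.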